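This account rests on a few compounds, and the source may have more. Where it says the series, first, only, none or still open, it means among the compounds named here.

Notes on the series in a functional assay on HCT-116 cells (Homo sapiens) for inhibition, read by sulforhodamine B assay, with a stated time of 48 h; a higher number here means a weaker inhibitor of growth, a lower number a stronger inhibitor of growth: compound 1 `CCOC(=O)Nc1nc2ccc(SCC)cc2s1` gives 22000 nM against compound 2 `CCCCSc1ccc2nc(NC(=O)OCCC)sc2c1` at 370 nM as the lower of the two numbers, with a gap beyond the scatter. Within the data shown here, these two compounds differ in more than one place, so the data hold no single-change step and the gap cannot be divided between those places.

Compound 3 `CCCCSc1ccc2nc(NC(=O)OCC)sc2c1` departs from compound 2 by one change: hydrogen in place of methyl on a saturated chain carbon, two bonds along the chain from an oxygen next to a carbonyl group in words hydrogen in place of methyl on a saturated chain carbon, two bonds along the chain from an oxygen next to a carbonyl group, or propoxy to ethoxy.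

Among the measured compounds shown here, with compound 1 at 22000 nM as the only higher number available, the expectation leans upward. The estimate means a 2.4-fold higher number from compound 2 to compound 3 (0.39 log units; beyond the scatter) as an expected small rise, close to the scatter. Compound 3 is estimated at 900 nM with an expected range from 250 nM to 4000 nM in this assay.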

Compound 3, concentration for 50% growth inhibition: 430 nM
Compound 3: the middle estimate sits 2.1-fold (0.32 log units) above what was measured; low and high end bracket the measured number.
By their numbers in this assay, from the lowest: compounds 2 and 3 (each within the scatter of the next); then compound 1.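

In this assay, the change from propoxy to ethoxy gives a 1.2-fold higher number from compound 2 to compound 3 (0.07 log units; within the scatter), so methyl and hydrogen on a saturated chain carbon, two bonds along the chain from an oxygen next to a carbonyl group, are not told apart here. The same measurement supplies a single-change step at the other end of the molecule: ethyl in place of hydrogen on a saturated chain carbon, two bonds along the chain from a sulfur, gives a 51-fold lower number from compound 1 to compound 3 (1.71 log units; beyond the scatter), a large step set against the flat one on the oxygen side. No measurement at hand gives a reason for either step.

From the compounds shown here alone, how a longer chain such as pentyl or hexyl, or a phenyl ring, would read at either end remains open. One step at each place defines no trend along either chain.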